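A few compounds are considered here, and "the series" means these few. Any claim that something is new, unique, unknown or untested is made for them only; others in the source may bear on it.

Measured compounds:
Compound 1 `Cc1ccc(COc2ccc(C(=O)/C=C/c3ccc(Cl)cc3)cc2)cc1` gives 12.3%.
Compound 2 `COc1ccc(/C=C/C(=O)c2ccc(OCc3ccccc3)cc2)cc1` gives 9.5%.

In a functional assay on HCT-116 cells (Homo sapiens) for antiproliferative activity, read by sulforhodamine B assay, with a stated time of 3 days, tested at 25 uM (on this read-out higher numbers stand for a stronger effect at the one concentration tested and lower numbers for a weaker effect), compound 2 stands lowest of the two numbers. Its nearest neighbour is compound 1, whose number is higher by a small amount that lies within the usual scatter, so the two values cannot be told apart and neither compound counts as the weaker one. Both numbers are small at the single concentration tested.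

Compound 3 `O=C(/C=C/c1ccc(Cl)cc1)c1ccc(OCc2ccccc2)cc1` has not yet been measured in this assay. It differs from compound 2 in one place: chloro in place of methoxy on an aromatic carbon. Among the measured compounds shown here, compound 1 also carries a chlorophenyl group and shows only a small number, so nothing among the measured compounds suggests that this change moves the read-out far. The step from compound 2 to compound 3 is therefore expected to be small and within the scatter, in no firm direction, as a number 1.5 percentage points higher from compound 2 to compound 3 (within the scatter). Compound 3 is estimated at 11%, with a range from 2% to 24%.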

Compound 3, a percentage reported as inhibition, at one concentration (the size of the read-out at that concentration, not a potency): 0.3%
Beside the measured number, compound 3's estimate is 10.7 percentage points above it, outside the stated range (below it).
By their numbers in this assay, from the lowest: compounds 3, 2 and 1 (each within the scatter of the next, the first and the last beyond it).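

In this assay, the change from 4-methoxyphenyl to 4-chlorophenyl, para to a large group, gives a number 9.2 percentage points lower from compound 2 to compound 3 (within the scatter) and so stays within the scatter, which means the two groups cannot be told apart at this position. Hydrogen in place of methyl on an aromatic carbon gives a number 12 percentage points lower from compound 1 to compound 3 (beyond the scatter) and is the one step here that lies beyond the scatter, though it is modest and all the numbers are small at the single concentration tested. Nothing given here bears on why either step has the size it has.

Going by these compounds, it remains open whether an amine or a carboxylic acid in place of the chloro would move the read-out beyond the scatter. On these data alone, it is equally open whether a longer chain in place of the methyl would do so.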